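The compounds below may be only part of what the source reports. "The series", "measured", "known", "first", "only" and "open" are said of these compounds alone.

Of the compounds shown here, three built on one shared core have been tested in an assay on CHO cells for displacement of a labelled ligand from Alpha-1A adrenergic receptor (Homo sapiens); on this read-out higher numbers stand for weaker inhibition and lower numbers for stronger inhibition. Compound 1 `COc1cccc(OC)c1OCCNCCOc1ccccc1OCc1ccccc1` gives 0.468 nM. Compound 2 `COc1cccc(OC)c1OCCNCCOc1ccccc1OCc1ccccc1Cl` gives 1.41 nM, and compound 3 `COc1cccc(OC)c1OCCNCCOc1ccccc1OCc1cccc(Cl)c1` gives 0.251 nM. Compound 3 therefore shows the lowest of the three numbers, but its gap to compound 1 lies within the scatter, so the two cannot be ranked; only its gap to compound 2 lies beyond the scatter.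

The next compound to be measured is compound 4 `COc1cccc(OC)c1OCCNCCOc1ccccc1OCc1ccc(Cl)cc1`. Set against compound 3, the change is 4-chlorophenyl in place of 3-chlorophenyl on a saturated chain carbon bound to an oxygen on an aromatic ring. Among the measured compounds shown here, three measured steps bear on this. Chloro in place of hydrogen on an aromatic carbon once gave a 3.0-fold higher number from compound 1 to compound 2 (0.48 log units; beyond the scatter), a step beyond the scatter, and once gave a 1.9-fold lower number from compound 1 to compound 3 (0.27 log units; within the scatter), a step within it. Exchanging one chlorophenyl for the other gave a 5.6-fold lower number from compound 2 to compound 3 (0.75 log units; beyond the scatter). None of these steps reaches a 4-chlorophenyl, so there is no direct guide; the two chlorophenyl groups already seen pull in different directions, which argues for caution rather than a confident direction. The step from compound 3 to compound 4 is expected to be a 1.6-fold higher number from compound 3 to compound 4 (0.20 log units; within the scatter), not clearly beyond the scatter. Compound 4 is thus estimated at 0.4 nM, with a range from 0.15 nM to 1.2 nM.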

Compound 4, inhibition constant: 0.251 nM
Estimate against measurement, compound 4: 1.6-fold (0.20 log units) above; low and high end bracket the measured number.
By their numbers in this assay, from the lowest: compounds 3, 4 and 1 (each within the scatter of the next); then compound 2.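

In this assay, 4-chlorophenyl in place of 3-chlorophenyl on a saturated chain carbon bound to an oxygen on an aromatic ring gives no change at the digits printed from compound 3 to compound 4 (within the scatter) and so does not separate these two groups. The 2-chlorophenyl group now stands alone among the three chlorophenyl groups: replacing it with 4-chlorophenyl gives a 5.6-fold lower number from compound 2 to compound 4 (0.75 log units; beyond the scatter) and matches in size the step already seen for 3-chlorophenyl, while chloro in place of hydrogen gives a 1.9-fold lower number from compound 1 to compound 4 (0.27 log units; within the scatter) and leaves compound 4 not separable from the compound without chlorine. No supporting measurement is available to explain why only the 2-chlorophenyl compound stands apart.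

The compounds shown leave open whether this result belongs to chlorine itself or would also appear with other groups at the same ring positions, such as fluoro or methoxy in 2-fluorophenyl or 2-methoxyphenyl. They also leave open how the read-out would respond to a longer chain, such as 2-phenylethyl in place of the benzyl group, or to a second chloro on the ring, as in 3,4-dichlorophenyl.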